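The compounds below may be only part of what the source reports. "The series", "measured", "known", "first", "only" and "open" are said of these compounds alone.

Measured in a toxicity assay on Vero cells (Chlorocebus sabaeus) for cytotoxicity, with a stated time of 48 h; a lower number here means that less compound is tolerated, a higher number that more compound is tolerated:
- Compound 1 `C=C1CC[C@@H]2[C@](C)(CO)[C@H](O)CC[C@@]2(C)[C@@H]1C/C=C1/C(=O)OC[C@@H]1Oc1cccc2ccc(C)nc12` gives 99800 nM
- Compound 2 `C=C1CC[C@@H]2[C@](C)(CO)[C@H](O)CC[C@@]2(C)[C@@H]1C/C=C1/C(=O)OC[C@@H]1Oc1cccc2cccnc12` gives 20800 nM
- Compound 3 `C=C1CC[C@@H]2[C@](C)(CO)[C@H](O)CC[C@@]2(C)[C@@H]1C/C=C1/C(=O)OC[C@@H]1Oc1c(Cl)cc(Cl)c2cccnc12` gives > 100000 nM

For compound 3, the entry > 100000 nM is a limit of the assay and not a number.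

Compound 2 stands lowest of the three. The data show a 4.8-fold lower number from compound 1 to compound 2 (0.68 log units; beyond the scatter) and an at least 4.8-fold higher number from compound 2 to compound 3 (0.68 log units; beyond the scatter), so it lies clear of both neighbours.

Compound 4 `C=C1CC[C@H]2[C@@](C)(CCC(O)[C@@]2(C)CO)[C@@H]1C/C=C1/C(=O)OC[C@H]1Oc1cccc2cccnc12` is the next to be read against compound 2. The two compounds have the same atoms and bonds, and the whole difference is stereochemical: the two compounds have the same atoms and bonds; at least one stereo element is drawn with a configuration in one of them and without one in the other: 2 of 7 stereo elements differ; a stereocentre at a saturated ring carbon is drawn R in compound 2 and without a configuration in compound 4; a stereocentre at a saturated ring carbon is drawn R in compound 2 and S in compound 4.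

Among the measured compounds shown here, none of the measured steps alters a stereo element. Each one changes the group on the oxygen, so they serve only as a yardstick for what this assay can show. The one fully readable size among them is a 4.8-fold lower number from compound 1 to compound 2 (0.68 log units; beyond the scatter), which is modest.

With no measured stereo change to draw on, the expectation in this assay is for no step beyond the scatter, and no direction is favoured. A modest shift in either direction remains possible, so the range is kept wide.

The expected outcome is a 1.2-fold higher number from compound 2 to compound 4 (0.08 log units; within the scatter) as an estimate. For compound 4 the estimated value is 25000 nM, with an expected range from 9000 nM to 70000 nM in this assay.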

Compound 4, half-maximal cytotoxic concentration: 22800 nM
Estimate against measurement, compound 4: 1.1-fold (0.04 log units) above, within the range that was stated.
By their numbers in this assay, from the lowest: compounds 2 and 4 (each within the scatter of the next); then compound 1. At a limit, above all of these: compound 3.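

In this assay, among the compounds shown here, this is the first step that changes stereochemistry and leaves the atoms and bonds as they are: a 1.1-fold higher number from compound 2 to compound 4 (0.04 log units; within the scatter). The readable exchange of the group on the oxygen separated its two compounds beyond the scatter, a 4.8-fold lower number from compound 1 to compound 2 (0.68 log units; beyond the scatter), whereas the different drawing of these two stereocentres at saturated ring carbons gives no such separation in this assay. The result therefore suggests that the tolerated concentration does not depend strongly on how these stereocentres are drawn, but it cannot be read as a clean comparison of two defined configurations because of this fact: the fact that one of compounds 2 and 4 is drawn with a defined configuration and the other without, at the place where they differ.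

As far as these compounds go, compound 2 and compound 4 both carry quinolin-8-yl on the oxygen, so it remains open whether the stereochemical difference would matter as little with 2-methylquinolin-8-yl or 5,7-dichloroquinolin-8-yl in that place. Also open, from the compounds shown here alone, is how this assay would respond if an amine or a carboxylic acid stood in place of the quinolin-8-yl group on the oxygen.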